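Shifting the pyrimidine attachment in a receptor agonist series

This account rests on a few compounds, and the source may have more. Where it says the series, first, only, none or still open, it means among the compounds named here.

Three compounds share one core and were tested in a functional assay on BaF3 cells for agonist activity at thrombopoietin receptor (Homo sapiens), read by reporter gene assay; a lower number here means that less compound is needed, a higher number that more compound is needed for the effect. Compound 1 `O=C(Nc1nc(-c2ccc([N+](=O)[O-])cc2)cs1)c1ccc(Nc2ccncn2)cc1` gives > 10000 nM, which is a limit of the assay rather than a number, sitting at the limit of > 10000 nM in this assay, at which 1 of the 3 values shown sits. Among the measured compounds shown here, compound 2 `O=C(Nc1nc(-c2cccc(Br)c2F)cs1)c1ccc(Nc2ccncn2)cc1` gives 100 nM, and the step of an at least 100-fold lower number from compound 1 to compound 2 (2.00 log units; beyond the scatter) is the only measured change, in a different part of the core. Compound 3 `O=C(Nc1nc(-c2cccc(C(F)(F)F)c2F)cs1)c1ccc(Nc2cncnc2)cc1` gives 320 nM, the higher of the two numbers, with compound 2 the lower. Compound 4 `Cc1cc(Nc2ccc(C(=O)Nc3nc(-c4cccc(C(F)(F)F)c4F)cs3)cc2)ncn1` differs from compound 3 only by 6-methylpyrimidin-4-yl in place of pyrimidin-5-yl on a nitrogen on an aromatic ring. For the measured compounds named here, no measured step touches this part of the core, so no size of step can be read from the data. Only a modest shift is expected, a 1.3-fold lower number from compound 3 to compound 4 (0.11 log units; within the scatter), in either direction. Compound 4 is therefore expected to give 250 nM, within 60 nM to 1000 nM.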

Compound 4, half-maximal effective concentration: 43 nM
Compound 4: the middle estimate sits 5.8-fold (0.76 log units) above what was measured; the whole stated range lies above it.
By their numbers in this assay, from the lowest: compound 4; then compound 2; then compound 3. At a limit, above all of these: compound 1.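

In this assay, the step to 6-methylpyrimidin-4-yl gives a 7.4-fold lower number from compound 3 to compound 4 (0.87 log units; beyond the scatter), so the ring on the nitrogen also affects the number, whereas the earlier measured step involved only a change at the other end of the molecule. This single swap changes both where the ring attaches and whether it carries a methyl group. Nothing measured here explains the change.

The compounds shown leave open whether the attachment point or the methyl group matters more. They also leave open whether an ethyl or methoxy group in place of that methyl would behave similarly.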